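A few compounds are considered here, and "the series" means these few. Any claim that something is new, unique, unknown or untested is made for them only; others in the source may bear on it.

For the measured compounds named here, in a functional assay on PC-3 cells (Homo sapiens) for inhibition, read by MTT assay, with a stated time of 48 h, tested at 10 uM (on this read-out higher numbers stand for more inhibition of growth at the one concentration tested and lower numbers for less inhibition of growth), three related compounds have numbers so far. Compound 1 `Cc1oc2c([C@H]3CCN(C)C[C@H]3O)c(O)cc(O)c2c(=O)c1C(O)c1ccc([N+](=O)[O-])cc1` gives 24%, compound 2 `Cc1oc2c([C@H]3CCN(C)C[C@H]3O)c(O)cc(O)c2c(=O)c1C(O)c1c(F)cccc1Cl` gives 0%, and compound 3 `CN1CC[C@H](c2c(O)cc(O)c3c(=O)cc(/C=C/c4ccccc4)oc23)[C@H](O)C1` gives 10%. The number for compound 3 lies within the usual scatter of that for compound 2 and clearly under that for compound 1.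

Compound 4 `CN1CC[C@H](c2c(O)cc(O)c3c(=O)cc(/C=C/c4ccc(Cl)cc4)oc23)[C@H](O)C1` differs from compound 3 in one place: chloro in place of hydrogen on an aromatic carbon. This is chloro in place of hydrogen on an aromatic carbon, which turns phenyl into 4-chlorophenyl.

Going by the values given here, only one measured step involves a change on an aromatic ring, and it sits on a different chain: a number 24 percentage points lower from compound 1 to compound 2 (beyond the scatter). That modest step swaps 4-nitrophenyl for 2-chloro-6-fluorophenyl, so it is a weak guide. Among the compounds with values here, no measured pair shows chloro added alone. No shift beyond the scatter is therefore expected, and the estimated change is a number 3 percentage points higher from compound 3 to compound 4 (within the scatter). For compound 4 the estimate is 13%, with an expected range of 0% to 30%.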

Compound 4, percent growth inhibition at one concentration: 12%
Compound 4: the middle estimate sits 1 percentage points above what was measured; low and high end bracket the measured number.
By their numbers in this assay, from the lowest: compounds 2, 3 and 4 (each within the scatter of the next, the first and the last beyond it); then compound 1.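

For the compounds shown here, this pair isolates chloro as the only change on an aromatic ring, and in this assay it gives a number 2 percentage points higher from compound 3 to compound 4 (within the scatter). On this 2-phenylethenyl chain, then, placing chloro para to a large group, which turns phenyl into 4-chlorophenyl, does not separate the two compounds at the one concentration tested, whereas the earlier step beyond the scatter exchanged one whole substituted phenyl for another on a different chain. Nothing measured here bears on the reason for this result.

Going by these compounds, it remains open whether an amine, a carboxylic acid or a methoxy group at this same place would give a number beyond the scatter of compound 3. On these data alone, it is also open whether chloro on another carbon of this ring would give a similar result.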